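Swapping trifluoromethyl for hydroxy on the anilide ring

The compounds below may be only part of what the source reports. "The series", "measured", "known", "first", "only" and "open" are said of these compounds alone.

Of the compounds shown here, three sharing one core have been measured in a functional assay on NCI-H23 cells (Homo sapiens) for cytotoxicity, read by sulforhodamine B assay, with a stated time of 72 h; on this read-out higher numbers stand for weaker inhibition of growth and lower numbers for stronger inhibition of growth. Compound 1 `CC(=O)N1c2ccccc2CCC1C(=O)Nc1ccccc1O` gives 65700 nM. Among the measured compounds shown here, compound 2 `O=C(Nc1ccccc1O)C1CCc2ccccc2N1C(=O)c1ccc(Cl)cc1` gives 19200 nM, and the change a 3.4-fold lower number from compound 1 to compound 2 (0.53 log units; beyond the scatter) is the only single-point step among the measured compounds. Compound 3 `O=C(Nc1ccccc1C(F)(F)F)C1CCc2ccccc2N1C(=O)c1ccccc1` gives 6340 nM, the lowest of the three numbers; compound 2 stands nearest to it and compound 1 furthest.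

Compound 4 `O=C(Nc1ccccc1O)C1CCc2ccccc2N1C(=O)c1ccccc1` differs from compound 3 by hydroxy in place of trifluoromethyl on an aromatic carbon. For the measured compounds named here, no measured step tests this exchange: the one known step concerns the acyl group, not the anilide ring. Compound 2, which carries the same hydroxy group, gives 19200 nM, and compound 3 gives 6340 nM; compound 4 is expected to land between them. The estimated step of a 2.4-fold higher number from compound 3 to compound 4 (0.37 log units; beyond the scatter) is modest but beyond the scatter. For compound 4 the expected value in this assay is 15000 nM, within a range of 4000 nM to 50000 nM.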

Compound 4, concentration for 50% growth inhibition: 3490 nM
Beside the measured number, compound 4's estimate is 4.3-fold (0.63 log units) above it, and the stated range ends above it.
By their numbers in this assay, from the lowest: compounds 4 and 3 (each within the scatter of the next); then compound 2; then compound 1.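

Hydroxy in place of trifluoromethyl on an aromatic carbon gives a 1.8-fold lower number from compound 3 to compound 4 (0.26 log units; within the scatter) in this assay, so at this position the compounds shown do not separate the two groups. With hydroxy held constant, the acyl side now accounts for the clearer differences: hydrogen in place of chloro gives a 5.5-fold lower number from compound 2 to compound 4 (0.74 log units; beyond the scatter) and phenyl in place of methyl gives a 19-fold lower number from compound 1 to compound 4 (1.27 log units; beyond the scatter), so adding chloro to the phenyl goes against the gain from methyl to phenyl. Nothing on hand explains any of these steps.

Going by these compounds, whether an amine, a carboxylic acid or a methoxy group at the same position would also stay level with hydroxy and trifluoromethyl remains open. On these data alone, it is also open whether chloro on the phenyl would have the same effect with trifluoromethyl on the other aromatic ring.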